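The source may hold more compounds than are shown below. What is called first, only, known or untested is meant among the compounds shown, and "the series" means these compounds.

Measured in a toxicity assay on NIH3T3 cells (Mus musculus) for cytotoxicity, read by resazurin assay; a higher number here means that more compound is needed for the effect, a lower number that less compound is needed:
Compound 1 `c1ccc(-c2ccc(Cn3cncc3CNc3cccc(-c4ccccc4)c3)cc2)cc1`: 10000 nM
Compound 2 `COC(=O)c1ccc(NCc2cncn2Cc2ccccc2Cl)cc1-c1ccccc1`: 10000 nM

Compound 1 stands level with compound 2 at the digits shown, within the scatter of repeated measurements. Compound 3 `CCC(=O)c1ccc(NCc2cncn2Cc2ccc(-c3ccccc3)cc2)cc1-c1ccccc1` departs from compound 1 by a single change propanoyl in place of hydrogen on an aromatic carbon, ortho to a phenyl group and para to a large group. Within the data shown here, no measured step shows what such a change does in this assay, so none beyond the scatter is expected. The estimated no change at the digits printed from compound 1 to compound 3 (within the scatter) therefore stays small. For compound 3 the expected value is 10000 nM, with an estimated range from 4000 nM to 20000 nM.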

Compound 3, half-maximal effective concentration: > 10000 nM
Compound 3: a limit, no number; the forecaster's own chance of this, stated with the estimate: 40%; the middle value lies on the limit itself.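

In this assay compound 3 gives > 10000 nM, which is a limit of the assay and not a number. Among these compounds, this gives the first reading for this position: propanoyl in place of hydrogen on this aromatic carbon, ortho to a phenyl group and para to a large group, gives a number no lower from compound 1 to compound 3 (the limit leaves the size open) as the step. The size of this step cannot be read: the limit of > 10000 nM in this assay, at which 1 of the 3 values shown sits.

The compounds shown leave open whether an amine or a carboxylic acid on the same carbon would lower the number in this assay.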